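The source may report more compounds than this note shows. Statements on the series, on what has been measured and on what is new or still open speak of the compounds shown alone.

Measured compounds in an ADME assay on TZM cells (Homo sapiens) for cytotoxicity, with a stated time of 1 days; a higher number here means that more compound is tolerated, a lower number that less compound is tolerated:
compound 1 `Cc1cc(CCC#N)cc(C)c1Oc1cc(Nc2ccc(C#N)cc2)c(N)cc1C(=O)NC(C)C`, compound 1 gives 184000 nM
compound 2 `Cc1cc(CCC#N)cc(C)c1Oc1cc(Nc2ccc(C#N)cc2)c(N)cc1CNC1CC1`, compound 2 gives 25500 nM
compound 3 `Cc1cc(CCC#N)cc(C)c1Oc1cc(Nc2ccc(C#N)cc2)c(N)cc1COC(=O)C1CC1`, compound 3 gives 42200 nM

Compound 1 stands highest of the three in this assay. Its nearest neighbour is compound 3: a 4.4-fold lower number from compound 1 to compound 3 (0.64 log units; beyond the scatter). The step to compound 2 is larger: a 7.2-fold lower number from compound 1 to compound 2 (0.86 log units; beyond the scatter). Between the two lower compounds the gap is small: a 1.7-fold higher number from compound 2 to compound 3 (0.22 log units; within the scatter).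

Compound 4 `COCc1cc(N)c(Nc2ccc(C#N)cc2)cc1Oc1c(C)cc(CCC#N)cc1C` is not yet measured. It differs from compound 1 as follows: methoxymethyl in place of isopropylcarbamoyl on an aromatic carbon.

The two measured steps from compound 1 both bear on this change, since each replaces the same isopropylcarbamoyl on that aromatic carbon with another substituent, and both moved the number down by a modest amount beyond the scatter. The entering methoxymethyl resembles neither the (cyclopropylamino)methyl of compound 2 nor the ((cyclopropylcarbonyl)oxy)methyl of compound 3 closely, so the size of the step is uncertain, but a downward step in this assay is the more likely outcome.

Compound 4 is therefore expected to come in below compound 1, with an estimated step of a 3.7-fold lower number from compound 1 to compound 4 (0.57 log units; beyond the scatter). The estimate for compound 4 is 50000 nM, with a range from 15000 nM to 160000 nM.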

Compound 4, half-maximal cytotoxic concentration: > 200000 nM
Compound 4 ended at the assay's limit; the forecaster's own chance of this, stated with the estimate: 5%; middle value at least 4.0-fold (0.60 log units) away from the limit.
By their numbers in this assay, from the lowest: compounds 2 and 3 (each within the scatter of the next); then compound 1. At a limit, above all of these: compound 4.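

In this assay, compound 4 stands at a limit of the assay and not at a number: the limit of > 200000 nM in this assay, at which 1 of the 4 values shown sits.

The step reads an at least 1.0-fold higher number from compound 1 to compound 4 (0.03 log units; that floor lies within the scatter), so losing the isopropylcarbamoyl on this aromatic carbon does not by itself bring the number down, as the steps to compound 2 and compound 3 alone might have suggested. What now separates the three compounds with a saturated chain carbon on this aromatic carbon is the group carried on that carbon: methyl in place of cyclopropylcarbonyl on the oxygen gives an at least 4.7-fold higher number from compound 3 to compound 4 (0.67 log units; beyond the scatter), and methoxy in place of cyclopropylamino gives an at least 7.8-fold higher number from compound 2 to compound 4 (0.89 log units; beyond the scatter).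

On these data alone, how far compound 4 lies from compound 1 stays open, as the limit gives only a floor that lies within the scatter. Also open, as far as these compounds go, is whether the number holds with other groups at this position, such as hydroxymethyl or dimethylaminomethyl, which would show whether the lower numbers of compound 2 and compound 3 go with their cyclopropyl parts or with the amine and ester links.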